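The compounds below may be only part of what the source reports. "The series", "measured", "known", "first", "only" and "open" are said of these compounds alone.

Values measured so far in a functional assay on MCF7 cells (Homo sapiens) for cytotoxicity, read by MTT assay, with a stated time of 96 h (on this read-out higher numbers stand for weaker inhibition and lower numbers for stronger inhibition), are as follows.

- Compound 1 (`N=C(N)c1ccc(-c2ccc(-c3cccc([N+](=O)[O-])c3)o2)cc1`) gives 3000 nM here
- Compound 2 (`Cc1ccc(-c2ccc(-c3ccc(C(=N)N)cc3)o2)cc1`) gives 4800 nM here

In this assay, among the measured compounds shown here, compound 2 stands at 4800 nM and compound 1 at 3000 nM as the only two numbers available. These two values lie within the usual scatter of each other, so neither compound can be ranked ahead of the other.

Compound 3 (`N=C(N)c1ccc(-c2ccc(-c3cccc(F)c3)o2)cc1`) has not been measured yet. It carries 3-fluorophenyl in place of 4-methylphenyl on an aromatic carbon and otherwise matches compound 2. For the measured compounds named here, no step between measured compounds shows what a swap of this kind does. Going by the values given here, the only guide is that compound 1 at 3000 nM and compound 2 at 4800 nM sit within the scatter of each other. The expectation in this assay is therefore no step beyond the scatter, in either direction. The expected change (a 1.3-fold lower number from compound 2 to compound 3 (0.10 log units; within the scatter)) is small. Compound 3 is estimated at 3800 nM with 1600 nM and 9000 nM as the ends of its expected range.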

Compound 3, half-maximal inhibitory concentration: 2600 nM
Estimate against measurement, compound 3: 1.5-fold (0.16 log units) above, within the range that was stated.
By their numbers in this assay, from the lowest: compounds 3, 1 and 2 (each within the scatter of the next).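

In this assay the step from 4-methylphenyl to 3-fluorophenyl, on the aromatic carbon next to the ring oxygen, is a 1.8-fold lower number from compound 2 to compound 3 (0.27 log units; within the scatter) and the swap of nitro for fluoro on the outer phenyl ring is a 1.2-fold lower number from compound 1 to compound 3 (0.06 log units; within the scatter) on this read-out. Among the compounds shown here, these are the first steps that can be read directly between measured compounds, and since both stay within the scatter, the three groups tried at this place cannot be told apart by cytotoxicity on these cells, whether the phenyl ring carries methyl, nitro or fluoro. Nothing measured here offers a reason for this flat result.

Going by these compounds, all three compounds keep a phenyl ring at this place, so it remains open whether a phenyl ring bearing an amine or a carboxylic acid would give a step beyond the scatter. On these data alone, it is also open whether the same holds once the phenyl ring itself gives way to a longer alkyl chain, which would test how much of this group the activity needs.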